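Swapping an amine substituent on a piperidine ring

This account rests on a few compounds, and the source may have more. Where it says the series, first, only, none or still open, it means among the compounds named here.

Measured compounds:
- compound 1, `CC(C)=CCN(C)C1CCN(CCCc2c[nH]c3ccc(-n4cnnc4)cc23)CC1`: 1.8 nM
- compound 2, `OC[C@H](NC1CCN(CCCc2c[nH]c3ccc(-n4ccnc4)cc23)CC1)c1ccccc1`: 0.8 nM

Of the compounds shown here, two have been measured in an assay on CHO cells for agonist activity at 5-hydroxytryptamine receptor 1D (Homo sapiens), read by GTPgammaS binding; a higher number here means that more compound is needed for the effect, a lower number that less compound is needed. Compound 1 gives 1.8 nM, the highest of the two numbers, meaning it needs the most compound for the effect. Compound 2 gives 0.8 nM, a lower number that lies beyond the usual scatter, so compound 2 needs less compound than compound 1. Compound 2 carries, on the same saturated ring carbon, an amine bearing a phenyl group together with a different aromatic ring on the core, so it is not a single-change neighbour of compound 1 and only the two values themselves can be compared.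

Compound 3, `C[C@H](NC1CCN(CCCc2c[nH]c3ccc(-n4cnnc4)cc23)CC1)c1ccccc1`, has not yet been measured. It differs from compound 1 in one place: (1-phenylethyl)amino in place of methyl(3-methylbut-2-en-1-yl)amino on a saturated ring carbon

Among the compounds with values here, no step between two measured compounds shows what this change alone does. Compound 3 shares the phenyl-bearing amine motif with compound 2, which gives 0.8 nM, so a small step toward a lower number is expected, of about a 1.8-fold lower number from compound 1 to compound 3 (0.26 log units; within the scatter). Compound 3 is therefore estimated to give 1 nM in this assay, within a range of 0.4 nM to 2.5 nM.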

Compound 3, half-maximal effective concentration: 12 nM
Beside the measured number, compound 3's estimate is 12-fold (1.08 log units) below it; measured number outside the range, above it.
By their numbers in this assay, from the lowest: compound 2; then compound 1; then compound 3.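

In this assay, within the data shown here, placing (1-phenylethyl)amino where methyl(3-methylbut-2-en-1-yl)amino stood on the saturated ring carbon gives a 6.7-fold higher number from compound 1 to compound 3 (0.82 log units; beyond the scatter), the first reading of a single change at this position, and it shows that the number responds to what is attached there. A phenyl group on this amine therefore does not by itself keep the number low on the core of compound 3, and the swap changes several things at once: it adds an aromatic ring, a hydrogen-bond donor and a defined stereocentre, and it removes a double bond outside aromatic rings. No measured evidence bears on which of these differences accounts for the step.

On these data alone, it remains open whether methyl(1-phenylethyl)amino, which would keep the aromatic ring without the amine hydrogen, would give a number closer to that of compound 1 or compound 3. The compounds shown also leave open how the opposite stereocentre, or a plain benzylamino group without the extra methyl, would behave at this position.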